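The source may report more compounds than this note shows. Statements on the series, on what has been measured and on what is new or still open speak of the compounds shown alone.

Measured so far:
- compound 1, `Cc1cccc2c1OCN(c1ccc3oc(-c4ccccc4)cc(=O)c3c1)C2`; compound 1 gives 72.4%
- compound 2, `O=c1cc(-c2ccccc2)oc2cc(N3COc4c(Br)cccc4C3)ccc12`; compound 2 gives 7.89%
- compound 3, `O=c1cc(-c2ccccc2)oc2ccc(N3COc4c(Br)cccc4C3)cc12`; compound 3 gives 71.6%

All three numbers come from a functional assay on MCF7 cells (Homo sapiens) for inhibition, read by MTT assay, with a stated time of 48 h, tested at 30 ug/mL; on this read-out lower numbers stand for less inhibition of growth and higher numbers for more inhibition of growth at the one concentration tested. Compound 3 and compound 1 share a core and differ in one place:

methyl in place of bromo on an aromatic carbon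

The step that goes with it is a number 0.8 percentage points higher from compound 3 to compound 1 (within the scatter). On this core the exchange of the halogen for the one-carbon group therefore leaves the read-out essentially where it was.

Compound 2 is built from the same atoms as compound 3, joined differently; the difference between the two cores is not broken down here. In this assay compound 2 stands lowest of the three numbers, with compound 3 and compound 1 both beyond the scatter above it, so the two cores clearly behave differently at the concentration tested.

Compound 4, `Cc1cccc2c1OCN(c1ccc3c(=O)cc(-c4ccccc4)oc3c1)C2`, has not yet been measured. It relates to compound 2 by the same change that relates compound 3 to compound 1:

methyl in place of bromo on an aromatic carbon

Because the step of a number 0.8 percentage points higher from compound 3 to compound 1 (within the scatter) lay within the scatter, the expectation for compound 4 is a step of similar size from compound 2, estimated as a number 2.1 percentage points higher from compound 2 to compound 4 (within the scatter). Compound 4 is accordingly expected to give about 10% in this assay. Among the compounds with values here, the estimate for compound 4 is placed between 0% and 25%, allowing for scatter and for the single precedent on which it rests. Measurement of compound 4 will show whether the change is indeed indifferent on the core of compound 2 as it was on the core of compound 3.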

Compound 4, percent growth inhibition at one concentration: 57.8%
The estimate for compound 4 lay 47.8 percentage points below the measured number; the measured number lies above the stated range.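

In this assay, methyl in place of bromo on an aromatic carbon gives a number 49.9 percentage points higher from compound 2 to compound 4 (beyond the scatter), and the size of the step does not carry over from one core to the other: the same change on two cores in this assay, a number 0.8 percentage points higher (within the scatter) from compound 3 to compound 1 and a number 49.9 percentage points higher (beyond the scatter) from compound 2 to compound 4, 49.1 percentage points apart, beyond the scatter of two such steps. Within the data shown here, the same exchange is thus indifferent on the core of compound 3 and large on the core of compound 2, so a step read on one of these cores is no guide to the step on the other. The two pairs do not show why the cores respond differently, which of the two responses would be typical of further cores in the series, or whether the gap reflects anything beyond growth inhibition at the one concentration tested.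

The compounds shown carry only bromo and methyl at this place, so it remains open whether chloro, methoxy, an amine or a longer chain such as propyl would follow the pair of compound 3 and compound 1 or the pair of compound 2 and compound 4. Also open, going by these compounds, is whether the difference between the two steps would persist at other concentrations than the one used in this assay.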